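Cytotoxicity in Blood Cells: Two Amides and an Ester

The source may hold more compounds than are shown below. What is called first, only, known or untested is meant among the compounds shown, and "the series" means these compounds.

Compound 1, `CC(CCNC(=O)c1c(Cl)cncc1Cl)N1CCC(C(Oc2ccncc2)c2ccc(Br)cc2)CC1`, gives 31200 nM in an ADME assay on PBMC cells (Homo sapiens) for cytotoxicity; a lower number here means that less compound is tolerated, a higher number that more compound is tolerated.
Compound 2, `Cc1ccnc(OC(c2ccc(C(F)(F)F)cc2)C2CCN(C(C)CCNC(=O)c3c(Cl)cncc3Cl)CC2)c1`, gives 33600 nM in this assay.

Of the two numbers in this assay, compound 2 holds the one that is nominally larger, yet compound 1 sits within the scatter of it, so neither compound can be called better tolerated than the other. Compound 3, `COC(=O)c1cccc(OC(c2ccc(C(F)(F)F)cc2)C2CCN(C(C)CCNC(=O)c3c(Cl)cncc3Cl)CC2)c1`, has not been measured. It differs from compound 2 in one place: 3-(methoxycarbonyl)phenyl in place of 4-methylpyridin-2-yl on an oxygen on a saturated carbon. For the measured compounds named here, no step between measured compounds exists to show what this change does to the half-maximal cytotoxic concentration, and the two measured compounds, which differ in several places, gave nearly the same number. The expectation for compound 3 is therefore a step from compound 2 that stays within the scatter, without a clear direction. Compound 3 is expected to give 30000 nM in this assay, with a likely range from 14000 nM to 64000 nM. The estimated step, a 1.1-fold lower number from compound 2 to compound 3 (0.05 log units; within the scatter), is expected to remain within the scatter.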

Compound 3, half-maximal cytotoxic concentration: 15200 nM
The estimate for compound 3 lay 2.0-fold (0.30 log units) above the measured number, within the range that was stated.
By their numbers in this assay, from the lowest: compound 3; then compounds 1 and 2 (each within the scatter of the next).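

For the compounds shown here, the change of 4-methylpyridin-2-yl to 3-(methoxycarbonyl)phenyl on an oxygen on a saturated carbon gives the first readable step at this position: in this assay it brings a 2.2-fold lower number from compound 2 to compound 3 (0.34 log units; beyond the scatter) and so shows that the group on this oxygen can shift the half-maximal cytotoxic concentration, if only modestly. Going by these compounds alone, the single step exchanges a ring with one hetero atom for a ring of carbon only and adds the methoxycarbonyl group at the same time, so it cannot assign the shift to either part. Nothing available bears on why the number moved.

On these data alone, it remains open whether the lower number follows the carbon-only ring or the methyl ester on it. A plain phenyl on the same oxygen, or a carboxylic acid in place of the methyl ester, would begin to separate the two.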